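Isopropyl for Cyclohexyl, Measured Once, Now Tried Again

This account rests on a few compounds, and the source may have more. Where it says the series, first, only, none or still open, it means among the compounds named here.

Of the compounds shown here, three have been measured in a physicochemical assay for solubility, with a stated time of 18 h, at pH 7.4; a higher number here means a more soluble compound, a lower number a less soluble compound. Compound 1 `CC(C)Cc1ccc2c(NCCCNCc3ccco3)ccnc2c1` gives 4200 nM. Compound 2 `c1coc(CNCCCNc2ccnc3cc(CC4CCCCC4)ccc23)c1` gives 4200 nM, and compound 3 `COc1ccc(F)cc1CNCCCNc1ccnc2cc(CC3CCCCC3)ccc12` gives 4200 nM. From compound 2 to compound 1 the change is isopropyl in place of cyclohexyl on a saturated chain carbon bound to an aromatic carbon, and in this assay it made no change at the digits printed from compound 2 to compound 1 (within the scatter). From compound 2 to compound 3 the change is 5-fluoro-2-methoxyphenyl in place of furan-2-yl on a saturated chain carbon bound to an amine nitrogen, which made no change at the digits printed from compound 2 to compound 3 (within the scatter). Compound 4 `COc1ccc(F)cc1CNCCCNc1ccnc2cc(CC(C)C)ccc12` awaits measurement. It differs from compound 3 by isopropyl in place of cyclohexyl on a saturated chain carbon bound to an aromatic carbon, the same change as that from compound 2 to compound 1, made here on the core of compound 3. Since that earlier step left the readout where it was, and compound 3 sits level with compound 1 and compound 2, compound 4 is expected to show no change at the digits printed from compound 3 to compound 4 (within the scatter). Compound 4 is therefore estimated at 4200 nM, within 2100 nM to 8400 nM.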

Compound 4, solubility: 4200 nM
For compound 4 middle estimate and measured number coincide at the digits printed; the range from low to high includes it.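

In this assay, isopropyl in place of cyclohexyl gave no change at the digits printed from compound 3 to compound 4 (within the scatter), matching no change at the digits printed from compound 2 to compound 1 (within the scatter), and the aryl exchange gave no change at the digits printed from compound 1 to compound 4 (within the scatter), matching no change at the digits printed from compound 2 to compound 3 (within the scatter), so both changes carried between these cores without a measurable step. Within the data shown here, this shows only that a step of no measurable size recurred across these four compounds; it does not show that the change would behave alike on any other core, or that a step of real size would carry over. Nothing available explains why the readings stayed level.

From the compounds shown here alone, whether a carboxylic acid or a longer chain in place of isopropyl would move the reading remains open.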